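A few compounds are considered here, and "the series" means these few. Any claim that something is new, unique, unknown or untested is made for them only; others in the source may bear on it.

For the measured compounds named here, in a functional assay for agonist activity at G protein-coupled receptor 88 (Homo sapiens), read by HTRF and cAMP accumulation (on this read-out lower numbers stand for an effect already at smaller amounts and higher numbers for an effect only at larger amounts of compound), compound 1 `NC1(CN(C(=O)[C@@H]2C[C@H]2c2ccccc2)c2ccc(-c3ccccc3)cc2)CCCC1` gives 0.57 nM and compound 2 `CCC(C)CNCCN(C(=O)[C@@H]1C[C@H]1c1ccccc1)c1ccc(-c2ccccc2)cc1` gives 4.7 nM; the single measured step is an 8.2-fold higher number from compound 1 to compound 2 (0.92 log units; beyond the scatter). Compound 3 `CC[C@H](C)[C@H](N)CN(C(=O)[C@@H]1C[C@H]1c1cccc(OC)c1)c1ccc(-c2ccccc2)cc1` gives 3000 nM, the highest of the three numbers, beyond the scatter from compound 2 and further still from compound 1. Compound 4 `CC[C@H](C)[C@H](N)CN(C(=O)[C@@H]1C[C@H]1c1c(F)cccc1F)c1ccc(-c2ccccc2)cc1` differs from compound 3 in one place: 2,6-difluorophenyl in place of 3-methoxyphenyl on a saturated ring carbon. Going by the values given here, the only measured step alters the group on the saturated chain carbon bound to the amide-type nitrogen, not the group on the saturated ring carbon, so no measured step bears on this change. The account therefore expects no step beyond the scatter, a 1.5-fold lower number from compound 3 to compound 4 (0.18 log units; within the scatter), with wide uncertainty. Compound 4 is estimated at 2000 nM in this assay, between 300 nM and 10000 nM.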

Compound 4, half-maximal effective concentration: 11000 nM
The estimate for compound 4 lay 5.5-fold (0.74 log units) below the measured number; the measured number lies above the stated range.
By their numbers in this assay, from the lowest: compound 1; then compound 2; then compound 3; then compound 4.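

In this assay, the group on the saturated ring carbon of the three-membered ring now has a measured effect of its own: 2,6-difluorophenyl in place of 3-methoxyphenyl gives a 3.7-fold higher number from compound 3 to compound 4 (0.56 log units; beyond the scatter). The earlier step concerned only the group on the saturated chain carbon, so it could not show this. Nothing available accounts for the direction of this step. The compounds shown do not separate losing the methoxy group from gaining the two fluorines. On these data alone, it also stays open where a plain phenyl or a pyridyl on this carbon would fall, with the side chain of compound 3.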